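This account rests on a few compounds, and the source may have more. Where it says the series, first, only, none or still open, it means among the compounds named here.

Compound 1, `CCc1cn([C@H]2C[C@H](N=[N+]=[N-])[C@@H](CO)O2)c(=O)[nH]c1=O`, is the starting point. In an ADME assay on Huh-7 cells (Homo sapiens) for cytotoxicity, read by thymidine incorporation (a higher number here means that more compound is tolerated, a lower number that less compound is tolerated), compound 1 gives > 100 ug/mL, which is a limit and not a number. Compound 2, `[N-]=[N+]=N[C@H]1C[C@H](n2cc(Cl)c(=O)[nH]c2=O)O[C@@H]1CO`, gives > 100 ug/mL, also a limit. Compound 3, `CCc1cn([C@H]2CC[C@@H](CO)O2)c(=O)[nH]c1=O`, gives > 100 ug/mL, again a limit. The whole set therefore comes down to the limit of > 100 ug/mL in this assay, at which 3 of the 3 values shown sit, and no exact value is available to anchor a prediction.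

Compound 4, `CCc1cn([C@H]2C[C@H](F)[C@@H](CO)O2)c(=O)[nH]c1=O`, differs from compound 1 by a single change: fluoro in place of azido on a saturated ring carbon. In words, this is fluoro in place of azido on a saturated ring carbon.

Among the compounds with values here, two measured steps bear on this change. The closer one alters the same ring carbon, putting hydrogen in place of azido: a step that the two limits leave unreadable from compound 1 to compound 3. The other puts chloro in place of ethyl on an aromatic carbon, elsewhere in the molecule: a step that the two limits leave unreadable from compound 1 to compound 2. Within the data shown here, neither step has a readable size, and no fluoro compound has been measured, so the evidence is thin. Even so, neither change brought a compound to a numerical value in this assay, so no shift in either direction beyond the usual scatter is expected. The expected change is a number no higher from compound 1 to compound 4 (the limit leaves the size open). Compound 4 is estimated at 100 ug/mL, with an expected range from 30 ug/mL to 200 ug/mL.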

Compound 4, half-maximal cytotoxic concentration: > 100 ug/mL
Compound 4: only a limit was reported; the forecaster's own chance of this, stated with the estimate: 65%; the middle value lies on the limit itself.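

In this assay compound 4 gives > 100 ug/mL, which is a limit and not a number. The steps from compound 1 and from compound 3 to compound 4 therefore cannot be read. The compounds shown leave open how far apart any of them truly lie, because the whole set rests on one limit: the limit of > 100 ug/mL in this assay, at which 4 of the 4 values shown sit.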